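Nitroimidazole piperazines: phenyl for ethoxycarbonyl and cytotoxicity

The compounds below may be only part of what the source reports. "The series", "measured", "known", "first", "only" and "open" are said of these compounds alone.

Compound 1 `CCOC(=O)N1CCN(CC(O)Cn2c([N+](=O)[O-])cnc2C)CC1` gives 3670000 nM in a toxicity assay on HeLa cells (Homo sapiens) for cytotoxicity, read by MTT assay, with a stated time of 24 h; on this read-out higher numbers stand for weaker inhibition and lower numbers for stronger inhibition. Compound 2 `Cc1ncc([N+](=O)[O-])n1CC(O)CN1CCN(c2ccccc2)CC1` reaches only the limit of the method, > 5000000 nM. The change between them, (phenyl in place of ethoxycarbonyl on an amine nitrogen in a ring), made a step of an at least 1.3-fold higher number from compound 1 to compound 2 (0.13 log units; that floor lies within the scatter), and that step is bounded by the limit of > 5000000 nM in this assay, at which 1 of the 3 values shown sits. Compound 3 `CCOC(=O)N1CCN(C(=S)SCC(O)Cn2cc([N+](=O)[O-])nc2C)CC1` gives 2360000 nM; how its core differs from that of compound 1 is not broken down here. Compound 4 `Cc1nc([N+](=O)[O-])cn1CC(O)CSC(=S)N1CCN(c2ccccc2)CC1` carries the same change as compound 2, (phenyl in place of ethoxycarbonyl on an amine nitrogen in a ring), with the place described identically. Among the measured compounds shown here, because an at least 1.3-fold higher number from compound 1 to compound 2 (0.13 log units; that floor lies within the scatter) was the only step seen for this change, the step from compound 3 to compound 4 is expected to be about a 1.9-fold higher number from compound 3 to compound 4 (0.28 log units; within the scatter). Compound 4 is therefore estimated at 4500000 nM, between 2000000 nM and 9000000 nM, with a real chance that this assay again reports only a limit.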

Compound 4, half-maximal inhibitory concentration: > 5000000 nM
Compound 4 gave a limit, no number; the forecaster's own chance of this, stated with the estimate: 40%; middle value at least 1.1-fold (0.04 log units) from the limit.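

In this assay, phenyl in place of ethoxycarbonyl on an amine nitrogen in a ring gives an at least 2.1-fold higher number from compound 3 to compound 4 (0.32 log units; beyond the scatter), and this is a floor rather than a full size. Compound 4 gives only a limit, > 5000000 nM. Carried to a second core, the change again gives a higher number, but a shared size for it is not established: the same change on two cores in this assay, an at least 1.3-fold higher number (0.13 log units; that floor lies within the scatter) from compound 1 to compound 2 and an at least 2.1-fold higher number (0.32 log units; beyond the scatter) from compound 3 to compound 4; the limit leaves it open whether they differ

The true size of the change on either core stays unread, and the series meets a ceiling here: the limit of > 5000000 nM in this assay, at which 2 of the 4 values shown sit. Open, going by these compounds, is whether a benzyl group or an acetyl group on that ring nitrogen would give a measurable number in this assay, and so a real size for a change at this place.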